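This account rests on a few compounds, and the source may have more. Where it says the series, first, only, none or still open, it means among the compounds named here.

Among the measured compounds shown here, in an ADME assay on microsomes from liver (Mus musculus) for metabolic stability, read by LC-MS, using NADPH, with a stated time of 10 min, tested at 10 uM (a lower number here means that the compound disappears faster, a higher number that the compound lasts longer), compound 1 `Nc1ncnc2c1c(Oc1cc(C(F)(F)F)ccn1)nn2[C@H]1CC[C@@H](N)CC1` gives 0.917 h, the only number among the three values so far. Compound 2 `N#Cc1ccnc(Oc2nn([C@H]3C[C@H](O)C3)c3ncnc(N)c23)c1` gives only a limit, > 2.41 h. Compound 3 `N#Cc1ccnc(Oc2nn([C@H]3C[C@@H](O)C3)c3ncnc(N)c23)c1` also gives only a limit, > 2.41 h.

Compound 4 `Nc1ncnc2c1c(Oc1cc(C(F)(F)F)ccn1)nn2[C@@H]1CC[C@H](N)C1` departs from compound 1 at a single place, 3-aminocyclopentyl in place of 4-aminocyclohexyl on an aromatic nitrogen.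

For the measured compounds named here, the only measured step is a step that the two limits leave unreadable from compound 2 to compound 3. It offers no size to borrow, and it concerns a different kind of change, namely (the fact that compounds 2 and 3 differ only in the configuration as drawn). Going by the values given here, no measured step involves a change of ring size at this nitrogen. The expectation in this assay therefore stays anchored on compound 1 at 0.917 h, with no direction favoured and no shift beyond the scatter foreseen. The expected outcome is a 1.0-fold lower number from compound 1 to compound 4 (0.01 log units; within the scatter). For compound 4 the estimated half-life is 0.9 h, with an expected range of 0.35 h to 2.2 h.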

Compound 4, half-life: 1.4 h
Beside the measured number, compound 4's estimate is 1.6-fold (0.19 log units) below it; low and high end bracket the measured number.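

In this assay, among the compounds shown here, this is the first readable step at the aromatic nitrogen, and the first to change ring size there: a 1.5-fold higher number from compound 1 to compound 4 (0.18 log units; within the scatter). On the shared core, 3-aminocyclopentyl in place of 4-aminocyclohexyl therefore does not separate the two compounds, a comparison that compound 2 and compound 3 could not offer, as each gives only a limit and the step between them cannot be read. No measured finding available here bears on why the half-life is kept across this ring change.

On these data alone, whether a piperidine or an open aminobutyl chain on this aromatic nitrogen would keep the half-life in the same range remains open. Also open, as far as these compounds go, is how the other stereoisomers of 3-aminocyclopentyl would compare with compound 4.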